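Phenyl in place of isobutyl: expectation for compound 4

A few compounds are considered here, and "the series" means these few. Any claim that something is new, unique, unknown or untested is made for them only; others in the source may bear on it.

Three members of the series have numbers in a functional assay on SW1573 cells (Homo sapiens) for antiproliferative activity, read by sulforhodamine B assay, with a stated time of 48 h; a lower number here means a stronger inhibitor of growth, a higher number a weaker inhibitor of growth. Compound 1 `Cc1ccc(S(=O)(=O)N2CC[C@@H](Cl)C[C@@H]2CC(C)C)cc1` gives 19000 nM, compound 2 `Cc1ccc(S(=O)(=O)N2CC[C@@H](Cl)C[C@@H]2C2CCCCC2)cc1` gives 53000 nM, and compound 3 `Cc1ccc(S(=O)(=O)N2CC[C@@H](Br)C[C@@H]2CC(C)C)cc1` gives 22000 nM. Compound 3 thus holds the second highest of the three numbers: the step of a 1.2-fold higher number from compound 1 to compound 3 (0.06 log units; within the scatter) lies within the scatter, while compound 2 shows a number beyond the scatter above that of compound 3. Compound 4 `Cc1ccc(S(=O)(=O)N2CC[C@@H](Br)C[C@@H]2c2ccccc2)cc1` is not yet measured. It differs from compound 3 by phenyl in place of isobutyl on a saturated ring carbon.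

Among the compounds with values here, only one measured step bears on this change: a 2.8-fold higher number from compound 1 to compound 2 (0.45 log units; beyond the scatter), where a six-membered saturated ring took the place of isobutyl. Phenyl is not cyclohexyl, and the series holds no other ring-for-chain exchange, which leaves the comparison loose. Within the data shown here, the one precedent nonetheless points to a modest rise in the number. The step from compound 3 to compound 4 is therefore expected to be about a 1.8-fold higher number from compound 3 to compound 4 (0.26 log units; within the scatter). Compound 4 is estimated at 40000 nM in this assay. The expected range for compound 4 runs from 15000 nM to 110000 nM.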

Compound 4, concentration for 50% growth inhibition: > 100000 nM
Compound 4: only a limit was reported (the forecaster's own chance of this, stated with the estimate: 10%); at least 2.5-fold (0.39 log units) between middle value and limit.
By their numbers in this assay, from the lowest: compounds 1 and 3 (each within the scatter of the next); then compound 2. At a limit, above all of these: compound 4.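

Compound 4 carries a limit, not a number, in this assay: the limit of > 100000 nM in this assay, at which 1 of the 4 values shown sits.

Phenyl in place of isobutyl gives an at least 4.5-fold higher number from compound 3 to compound 4 (0.65 log units; beyond the scatter), so this saturated ring carbon next to the ring nitrogen has now yielded a step whose full size cannot be read. The earlier exchange at this carbon, a 2.8-fold higher number from compound 1 to compound 2 (0.45 log units; beyond the scatter), ended at a number, so the series now holds two ring-for-isobutyl steps, both upward, though on different halogen backgrounds, and the two cannot be ranked firmly from a limit.

Whether the ring's aromatic character matters stays open, since compound 2 and compound 4 differ in two places and a cyclohexyl partner with bromo is absent from the compounds shown. Also open, on these data alone, is how a benzyl group, with its ring set one carbon away, or a phenyl bearing an amine would behave at this carbon.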